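Methoxymethyl to difluoromethyl on the series' aromatic ring

The source may report more compounds than this note shows. Statements on the series, on what has been measured and on what is new or still open speak of the compounds shown alone.

In a physicochemical assay for lipophilicity (a higher number here means a more lipophilic compound, a lower number a more polar compound), compound 1 `C[C@H](NC(=O)c1cc(C(F)(F)F)nn1C)c1nc(-c2ccnc(N(C)C)c2)no1` gives 3.9 and compound 2 `COCc1cc(-c2noc([C@H](C)NC(=O)c3cc(C(F)(F)F)nn3C)n2)ccn1` gives 3, the lower of the two numbers. Compound 3 `C[C@H](NC(=O)c1cc(C(F)(F)F)nn1C)c1nc(-c2ccnc(C(F)F)c2)no1` has difluoromethyl in place of methoxymethyl on an aromatic carbon. For the measured compounds named here, one measured step bears on this place: a number 0.90 log units lower from compound 1 to compound 2 (beyond the scatter), modest and beyond the scatter, with methoxymethyl in place of dimethylamino. It involves a different exchange, so it serves only as a guide to size. The expected step is a number 0.60 log units higher from compound 2 to compound 3 (beyond the scatter), upward and beyond the scatter. The estimate for compound 3 is 3.6, with an expected range from 3.2 to 4.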

Compound 3, distribution coefficient: 3.4
The estimate for compound 3 lay 0.20 log units above the measured number, within the range that was stated.
By their numbers in this assay, from the lowest: compound 2; then compound 3; then compound 1.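

In this assay at this position, difluoromethyl in place of methoxymethyl gives a number 0.40 log units higher from compound 2 to compound 3 (beyond the scatter) and in place of dimethylamino gives a number 0.50 log units lower from compound 1 to compound 3 (beyond the scatter) on the same core. The three groups therefore now have an order here: methoxymethyl lowest, then difluoromethyl, then dimethylamino. Nothing available accounts for these differences.

Still open, from the compounds shown here alone, is where a carboxylic acid or a longer ether chain at this aromatic carbon would fall in that order. Going by these compounds, whether the same order holds on any other core also remains open.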